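The source may report more compounds than this note shows. Statements on the series, on what has been measured and on what is new or still open speak of the compounds shown alone.

Measured in a functional assay on HCT-15 cells (Homo sapiens) for antiproliferative activity, read by sulforhodamine B assay, with a stated time of 72 h; a lower number here means a stronger inhibitor, a higher number a weaker inhibitor:
Compound 1 `COc1cc(/C=C/COC(C)=O)ccc1OC(C)=O`: 3260 nM
Compound 2 `CCCC(=O)OC/C=C/c1ccc(OC(=O)CCC)c(OC)c1`: 28800 nM
Compound 3 `CCCC(=O)OC/C=C/c1ccc(OC(C)=O)c(OC)c1`: 22800 nM

Compound 3 sits within the scatter of compound 2, while its number lies beyond the scatter above that of compound 1. Compound 4 `CC[C@H](C)C(=O)OC/C=C/c1ccc(OC(C)=O)c(OC)c1` differs from compound 3 by one change: methyl in place of hydrogen on a saturated chain carbon bound to a carbonyl carbon and a saturated chain carbon, turning propyl to sec-butyl. The same chain gave a 7.0-fold higher number from compound 1 to compound 3 (0.84 log units; beyond the scatter) when ethyl replaced hydrogen, a modest step. The other chain gave a 1.3-fold lower number from compound 2 to compound 3 (0.10 log units; within the scatter), within the scatter. Adding methyl to a chain already lengthened, one might expect little further movement in this assay, with nothing beyond the scatter and any drift towards a higher number. The expected step is a 1.1-fold higher number from compound 3 to compound 4 (0.04 log units; within the scatter). For compound 4 the estimate is 25000 nM, with an expected range from 10000 nM to 60000 nM.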

Compound 4, half-maximal inhibitory concentration: 34100 nM
Compound 4: middle estimate off by 1.4-fold (0.13 log units), on the low side; measured number inside the range.
By their numbers in this assay, from the lowest: compound 1; then compounds 3, 2 and 4 (each within the scatter of the next).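

Turning propyl to sec-butyl at this position gives a 1.5-fold higher number from compound 3 to compound 4 (0.17 log units; within the scatter) in this assay, so this branch adds no change beyond the scatter. Sec-butyl in place of methyl on a carbonyl carbon gives a 10-fold higher number from compound 1 to compound 4 (1.02 log units; beyond the scatter), which places the large loss with leaving the methyl of compound 1 rather than with the branch itself. No measurement here explains either step. The compounds shown leave open whether a longer chain or an amine on this carbonyl carbon would behave like the sec-butyl of compound 4. They also leave open how the opposite sec-butyl stereoisomer would compare.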